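The source may report more compounds than this note shows. Statements on the series, on what has been measured and on what is new or still open speak of the compounds shown alone.

Among the compounds with values here, compound 2 `CN(C)CCn1cnnc1-c1cc(Oc2ccc(NC(=O)N/N=C/c3cccc(Cl)c3Cl)cc2F)ccn1` gives, in a functional assay on U-87MG ATCC cells (Homo sapiens) for cytotoxicity, read by MTT assay, with a stated time of 72 h (a higher number here means a weaker inhibitor, a lower number a stronger inhibitor), 13200 nM, the higher of the two numbers measured so far; compound 1 `COc1ccc(OC)c(/C=N/NC(=O)Nc2ccc(Oc3ccnc(-c4nncn4CCN(C)C)c3)c(F)c2)c1` gives 6400 nM. Compound 3 `COc1cc(/C=N/NC(=O)Nc2ccc(Oc3ccnc(-c4nncn4CCN(C)C)c3)c(F)c2)ccc1O` has not yet been measured. It differs from compound 2 in one place: 4-hydroxy-3-methoxyphenyl in place of 2,3-dichlorophenyl on a carbon with a double bond to nitrogen. Within the data shown here, one measured step bears on this, since it exchanged the 2,5-dimethoxyphenyl ring for the same 2,3-dichlorophenyl ring: a 2.1-fold higher number from compound 1 to compound 2 (0.31 log units; beyond the scatter). Undoing that kind of exchange, a step of similar size in the opposite direction is expected in this assay, a 1.9-fold lower number from compound 2 to compound 3 (0.28 log units; within the scatter). Compound 3 is therefore estimated at 7000 nM, with a range from 3000 nM to 16000 nM.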

Compound 3, half-maximal inhibitory concentration: > 100000 nM
Compound 3 ended at the assay's limit (the forecaster's own chance of this, stated with the estimate: 5%); at least 14-fold (1.15 log units) between middle value and limit.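

In this assay, compound 3 reads > 100000 nM, a limit of the assay and not a number: the limit of > 100000 nM in this assay, at which 1 of the 3 values shown sits.

Swapping the ring on this carbon with a double bond to nitrogen can therefore matter far more than the modest 2.1-fold higher number from compound 1 to compound 2 (0.31 log units; beyond the scatter) suggested, with an at least 7.5-fold higher number from compound 2 to compound 3 (0.87 log units; beyond the scatter) and an at least 15-fold higher number from compound 1 to compound 3 (1.19 log units; beyond the scatter). Among these three compounds, the 4-hydroxy-3-methoxyphenyl ring alone goes with this large shift.

Going by these compounds, whether the hydroxy group by itself goes with the shift remains open. Also open, on these data alone, is how a phenyl ring carrying an amine or a carboxylic acid would behave here.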